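Cytotoxicity of a Shared Core: Three Measured, One Expected

The source may hold more compounds than are shown below. What is called first, only, known or untested is meant among the compounds shown, and "the series" means these compounds.

Compound 1, `O=C1c2ccccc2C(=O)N1CCOC(=S)N(C(=O)c1cccnc1Cl)c1ccc(Br)cc1`, > 100000 nM
Compound 2, `Cc1ccc(N(C(=O)c2cccc(C)c2)C(=S)OCCN2C(=O)c3ccccc3C2=O)cc1`, > 100000 nM
Compound 3, `O=C1c2ccccc2C(=O)N1CCOC(=S)N(C(=O)c1ccc(F)c(F)c1)c1ccc(Cl)cc1`, 52000 nM

All three compounds share one core and were tested in an ADME assay on MT4 cells (Homo sapiens) for cytotoxicity, read by MTT assay; on this read-out higher numbers stand for lower toxicity in this test and lower numbers for higher toxicity in this test. For compound 1 the result > 100000 nM is a limit of the assay and not a number. For compound 2 the result > 100000 nM is likewise a limit. Two of the three results thus sit at the limit of > 100000 nM in this assay, at which 2 of the 3 values shown sit. Compound 3 is the only one of the three with an actual number, and in this assay compound 3 gives 52000 nM.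

Compound 4, `O=C1c2ccccc2C(=O)N1CCOC(=S)N(C(=O)c1cccc2ccccc12)c1ccc(Cl)cc1`, has not yet been measured. It differs from compound 3 in one place: naphthalen-1-yl in place of 3,4-difluorophenyl on a carbonyl carbon. Within the data shown here, no step between measured compounds is available here, so this change has no measured precedent in the set. The expected step, a 1.0-fold lower number from compound 3 to compound 4 (0.02 log units; within the scatter), is one that stays within the usual scatter, in no clear direction. Compound 4 is accordingly expected to give about 50000 nM, with a likely range from 20000 nM to 120000 nM.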

Compound 4, half-maximal cytotoxic concentration: 6000 nM
For compound 4 the middle estimate is 8.3-fold (0.92 log units) above the measured one; measured number below the stated range.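

In this assay the change to naphthalen-1-yl in place of 3,4-difluorophenyl on a carbonyl carbon brings an 8.7-fold lower number from compound 3 to compound 4 (0.94 log units; beyond the scatter) and so points toward higher toxicity in this test. Among these compounds, the earlier compounds offered no step at all, so this is the first sign that the group at this position matters to the read-out: everything else in the molecule stays the same, and the number still moves. Nothing shown gives a measured property that could account for this step.

This single step cannot separate the effect of the second aromatic ring of naphthalen-1-yl from the effect of losing the fluorine atoms. The compounds shown also leave open how this assay would read with a group carrying an amine or a carboxylic acid on this carbonyl carbon.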